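This account rests on a few compounds, and the source may have more. Where it says the series, first, only, none or still open, it means among the compounds named here.

Compound 1 `CC1CCC(Nc2nc(C(F)(F)F)ccc2CNC(=O)C(C)c2ccc(NS(C)(=O)=O)c(F)c2)CC1` gives 1130 nM in a functional assay on CHO-K1 cells for antagonist activity at transient receptor potential cation channel subfamily V member 1 (Homo sapiens), read by FLIPR; a lower number here means a stronger inhibitor, a higher number a weaker inhibitor. Compound 2 `CC(C(=O)NCc1ccc(C(F)(F)F)nc1NCc1ccc(Cl)cc1)c1ccc(NS(C)(=O)=O)c(F)c1` gives 414 nM. Compound 3 `CC(C(=O)NCc1ccc(C(F)(F)F)nc1N1CCC(C)(C)CC1)c1ccc(NS(C)(=O)=O)c(F)c1` gives 8 nM.

Compound 3 stands lowest of the three, with a 52-fold lower number from compound 2 to compound 3 (1.71 log units; beyond the scatter) and a 140-fold lower number from compound 1 to compound 3 (2.15 log units; beyond the scatter). Compound 4 `CC(C(=O)NCc1ccc(C(F)(F)F)nc1N1CCC(c2ccccc2)CC1)c1ccc(NS(C)(=O)=O)c(F)c1` differs from compound 3 in one place: 4-phenylpiperidin-1-yl in place of 4,4-dimethylpiperidin-1-yl on an aromatic carbon. Both large measured steps concern the attachment on the aromatic carbon, which compound 4 keeps; the smaller one, a 2.7-fold lower number from compound 1 to compound 2 (0.44 log units; beyond the scatter), swaps groups on a nitrogen that compound 4 no longer carries. Among the compounds with values here, no measured step exchanges one piperidine for another, so the direction is uncertain. Compound 4 is therefore expected to show a 2.5-fold higher number from compound 3 to compound 4 (0.40 log units; beyond the scatter), and its estimated value in this assay is 20 nM, in a range from 5 nM to 80 nM.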

Compound 4, half-maximal inhibitory concentration: 25 nM
Compound 4: middle estimate off by 1.3-fold (0.10 log units), on the low side; the measured number falls inside the stated range.
By their numbers in this assay, from the lowest: compound 3; then compound 4; then compound 2; then compound 1.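

At this aromatic carbon next to the ring nitrogen, the 4-position of the piperidine accepts a whole added aromatic ring in this assay with only a modest loss, as a 3.1-fold higher number from compound 3 to compound 4 (0.49 log units; beyond the scatter) shows. The advantage over the amino-linked groups therefore does not belong to 4,4-dimethylpiperidin-1-yl alone, since a 17-fold lower number from compound 2 to compound 4 (1.22 log units; beyond the scatter) and a 45-fold lower number from compound 1 to compound 4 (1.66 log units; beyond the scatter) also favour the piperidine. No available evidence explains these steps. The compounds shown leave open how a piperazine would read in place of the piperidine, and what a chlorine or an amine on the added phenyl ring would do.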